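Swapping the benzyl substituent for a small ester side chain

The compounds below may be only part of what the source reports. "The series", "measured", "known", "first", "only" and "open" are said of these compounds alone.

Compound 3 `Cc1cc(C)c(Oc2cc(Nc3ccc(C#N)cc3)ncc2C(=O)NCc2cn(Cc3cccc(Cl)c3)nn2)c(C)c1` carries a 3-chlorobenzyl group on the saturated chain carbon bound to an aromatic nitrogen of the shared core. In an ADME assay on MT4 cells (Homo sapiens) for cytotoxicity, read by MTT assay, with a stated time of 5 days (a higher number here means that more compound is tolerated, a lower number that less compound is tolerated), compound 3 gives 187000 nM. Its close relative compound 2 `Cc1cccc(Cn2cc(CNC(=O)c3cnc(Nc4ccc(C#N)cc4)cc3Oc3c(C)cc(C)cc3C)nn2)c1` gives 114000 nM in this assay, and the step of a 1.6-fold higher number from compound 2 to compound 3 (0.21 log units; within the scatter) shows the two numbers sit within the scatter of each other. Compound 1 `Cc1cc(C)c(Oc2cc(Nc3ccc(C#N)cc3)ncc2C(=O)NCc2cn(Cc3ccccc3F)nn2)c(C)c1` reaches only a limit of this assay, > 222000 nM, so for compound 1 no number is known (the limit of > 222000 nM in this assay, at which 1 of the 3 values shown sits).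

Compound 4 `COC(=O)Cn1cc(CNC(=O)c2cnc(Nc3ccc(C#N)cc3)cc2Oc2c(C)cc(C)cc2C)nn1` has not been measured. It differs from compound 3 in one place: methoxycarbonyl in place of 3-chlorophenyl on a saturated chain carbon bound to an aromatic nitrogen. The two measured steps made at the same place, an at least 1.9-fold lower number from compound 1 to compound 2 (0.28 log units; that floor lies within the scatter) and an at least 1.1-fold lower number from compound 1 to compound 3 (0.07 log units; that floor lies within the scatter), both start from a limit and stay within the scatter, so neither gives a direction for exchanging the group at this position. Everything measured so far sits at high concentrations, and the change to a methoxycarbonyl group gives no reason in the data for a shift beyond the scatter. The expected step of a 1.1-fold higher number from compound 3 to compound 4 (0.03 log units; within the scatter) is therefore essentially flat. Compound 4 is estimated at 200000 nM, with a likely range from 80000 nM to 500000 nM, and a real chance that this assay again reports only a limit.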

Compound 4, half-maximal cytotoxic concentration: 13800 nM
For compound 4 the middle estimate is 14-fold (1.16 log units) above the measured one, outside the stated range (below it).
By their numbers in this assay, from the lowest: compound 4; then compounds 2 and 3 (each within the scatter of the next). At a limit, above all of these: compound 1.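

The earlier compounds shown here all carry a substituted phenyl ring at this place, and the steps among them stay within the scatter, so the position looked indifferent in this assay. The (methoxycarbonyl)methyl group of compound 4 shows that it is not, with a 14-fold lower number from compound 3 to compound 4 (1.13 log units; beyond the scatter) and an 8.3-fold lower number from compound 2 to compound 4 (0.92 log units; beyond the scatter), so exchanging the ring for this small ester matters far more here than changing the substituent on the ring. The third step, an at least 16-fold lower number from compound 1 to compound 4 (1.20 log units; beyond the scatter), points the same way, but it starts from a limit and not from a number, so it gives only a floor: the limit of > 222000 nM in this assay, at which 1 of the 4 values shown sits.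

A single compound cannot tell whether the lower number goes with the loss of the phenyl ring or with the ester itself, since methoxycarbonyl removes the ring and brings in a carbonyl in one change. A plain alkyl chain such as ethyl, a carboxylic acid or a primary amide at this place would help separate those two readings, and nothing shown here says why the number falls.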